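This account rests on a few compounds, and the source may have more. Where it says the series, first, only, none or still open, it means among the compounds named here.

Two compounds have been measured in a functional assay on HOP-92 cells (Homo sapiens) for inhibition, read by sulforhodamine B assay, with a stated time of 48 h; on this read-out higher numbers stand for weaker inhibition of growth and lower numbers for stronger inhibition of growth:

Compound 1, `CC(=O)/C(=C\c1c(-c2ccccc2)[nH]c2ccccc12)S(=O)(=O)c1ccccc1`, gives 5900 nM.
Compound 2, `N#C/C(=C\c1c(-c2ccccc2)[nH]c2ccccc12)S(=O)(=O)c1ccccc1`, gives 10300 nM.

Compound 2 gives the higher of the two numbers, yet the step of a 1.7-fold higher number from compound 1 to compound 2 (0.24 log units; within the scatter) lies within the scatter, so the two compounds cannot be told apart on these data. Among the compounds with values here, that step swaps the group on one chain carbon while the phenylsulfonyl stays in place, and it is the only measured step in this set.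

Compound 3, `N#C/C(=C\c1c(-c2ccccc2)[nH]c2ccccc12)C(=O)c1ccccc1`, differs from compound 2 in another way: benzoyl in place of phenylsulfonyl on a double-bonded chain carbon bound to a double-bonded chain carbon and a triple-bonded carbon. Within the data shown here, no measured step touches this position, so nothing here shows how exchanging a phenylsulfonyl for a benzoyl on this chain carbon moves the number in this assay. Among the measured compounds shown here, the one available step, from compound 1 to compound 2, changed a different group and stayed within the scatter, which gives no reason to expect a shift in either direction for compound 3.

Compound 3 is therefore expected to show a step of a 1.0-fold lower number from compound 2 to compound 3 (0.01 log units; within the scatter), that is, no change beyond the scatter, with an estimated value of 10000 nM and a range from 3000 nM to 35000 nM.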

Compound 3, concentration for 50% growth inhibition: 4500 nM
Compound 3: the middle estimate sits 2.2-fold (0.35 log units) above what was measured; low and high end bracket the measured number.
By their numbers in this assay, from the lowest: compounds 3, 1 and 2 (each within the scatter of the next, the first and the last beyond it).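

In this assay, benzoyl in place of phenylsulfonyl produces a 2.3-fold lower number from compound 2 to compound 3 (0.36 log units; beyond the scatter) and thus a modest move toward stronger inhibition of growth. This is the first step in the set to lie beyond the scatter, so this chain carbon, bound to a double-bonded chain carbon and a triple-bonded carbon, is shown to be a place where a change can move the number, whereas the step from acetyl to cyano could not be told apart from repeat-to-repeat variation. The exchange keeps a six-membered aromatic ring of carbon only and replaces a sulfur-containing group with a carbonyl-containing one, but no supporting measurement bears on why the number moves.

A single step cannot show whether an amide or a carboxylic acid on this chain carbon would push the number further or back the other way. On these data alone, it also remains open whether benzoyl in place of phenylsulfonyl gives a similar step when acetyl stands in place of the cyano.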